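Chloro to bromo on the shared core

The source may hold more compounds than are shown below. What is called first, only, known or untested is meant among the compounds shown, and "the series" means these compounds.

Measured so far:
compound 1, `COc1ccc(Br)c(-c2nc3ncccc3o2)c1`: 8%
compound 2, `Clc1ccccc1-c1nc2ncccc2o1`: 38%

In a functional assay on the whole organism for inhibition, with Rattus norvegicus as the target, at a dose of 30 mg/kg (on this read-out higher numbers stand for more inhibition at the one dose given (going by the name of the read-out) and lower numbers for less inhibition), compound 2 gives the highest of the two numbers; compound 1 is the nearest, a gap beyond the scatter. For the measured compounds named here, no step between measured compounds is available. Compound 3 `Brc1ccccc1-c1nc2ncccc2o1` differs from compound 2 as follows: bromo in place of chloro on an aromatic carbon. For a swap of this size the expected step in this assay is small, in no clear direction, and not beyond the scatter. Compound 3 is therefore estimated at 36%, with a range from 15% to 56%. The expected step of a number 2 percentage points lower from compound 2 to compound 3 (within the scatter) stays within the scatter.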

Compound 3, a percentage reported as inhibition, in the whole organism at one dose (the size of the read-out at that dose, not a potency): 24%
Beside the measured number, compound 3's estimate is 12 percentage points above it; the range from low to high includes it.
By their numbers in this assay, from the lowest: compound 1; then compound 3; then compound 2.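

Compound 3 links the two earlier compounds through single changes, which they did not offer on their own. In this assay, this aromatic carbon is sensitive to the halogen, with bromo in place of chloro giving a number 14 percentage points lower from compound 2 to compound 3 (beyond the scatter), while hydrogen in place of methoxy on an aromatic carbon gives a number 16 percentage points higher from compound 1 to compound 3 (beyond the scatter) on the bromo compounds. No measurement at hand accounts for either step.

Open, on these data alone, is whether fluoro or an amine on the same aromatic carbon would extend the halogen comparison. Also open, as far as these compounds go, is whether a carboxylic acid in place of methoxy would read like hydrogen.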